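This account rests on a few compounds, and the source may have more. Where it says the series, first, only, none or still open, it means among the compounds named here.

Among the measured compounds shown here, compound 1 `O=C(/C=C(O)/C=C/c1ccc(O)cc1)c1cc(Cl)ccc1O` gives 45.3% in an assay on isolated protein for inhibition of Alpha glucosidase (Homo sapiens), with stated times of 5 min and 15 min, tested at 50 uM (a lower number here means less inhibition, a higher number more inhibition at the concentration tested (going by the name of the read-out)), the higher of the two numbers measured so far. Compound 2 `O=C(/C=C(O)/C=C/c1ccc(O)cc1)c1ccccc1O` gives 20.4% in this assay, and the step of a number 24.9 percentage points lower from compound 1 to compound 2 (beyond the scatter) follows from a hydrogen in place of chloro on an aromatic carbon. Compound 3 `O=C(/C=C(O)/C=C/c1cccc(O)c1)c1cc(Cl)ccc1O` differs from compound 1 at a different part of the structure: 3-hydroxyphenyl in place of 4-hydroxyphenyl on a double-bonded chain carbon bound to a double-bonded chain carbon. For the measured compounds named here, no measured step touches that part, so the change is expected to bring no shift beyond the scatter, a number 0.3 percentage points lower from compound 1 to compound 3 (within the scatter). Compound 3 is therefore estimated at 45%, between 25% and 62%.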

Compound 3, a percentage reported as inhibition, at one concentration (the size of the read-out at that concentration, not a potency): 62.4%
Estimate against measurement, compound 3: 17.4 percentage points below; measured number above the stated range.
By their numbers in this assay, from the lowest: compound 2; then compound 1; then compound 3.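

Read in this assay as the only measure, the swap of 4-hydroxyphenyl for 3-hydroxyphenyl gives a number 17.1 percentage points higher from compound 1 to compound 3 (beyond the scatter) and so shows that this part of the structure matters, which the earlier pair could not show. The two groups have the same atoms and the same counts of hydrogen-bond donors and acceptors, so the gap comes with a change in how those atoms are joined. Nothing available explains the rise. Still open, from the compounds shown here alone, is whether 3-hydroxyphenyl raises the number without the chloro, and whether 3-methoxyphenyl or 3-aminophenyl would do the same.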